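Swapping chloro for hydroxy on compound 3

The compounds below may be only part of what the source reports. "The series", "measured", "known", "first", "only" and "open" are said of these compounds alone.

Measured in a functional assay on SW-620 cells (Homo sapiens); a lower number here means a stronger inhibitor of growth, a higher number a weaker inhibitor of growth:
- compound 1 `O=S(=O)(/C=C/c1ccc(Br)cc1)Cc1ccc(Nc2ncnc3ccccc23)cc1`: > 100000 nM (a limit)
- compound 2 `CC(C)(C)c1cc(/C=C/S(=O)(=O)Cc2ccc(Nc3ncnc4ccccc34)cc2)cc(C(C)(C)C)c1O`: 9000 nM
- compound 3 `O=S(=O)(/C=C/c1ccc(Cl)cc1)Cc1ccc(Nc2ncnc3ccccc23)cc1`: 77000 nM

Of the two true numbers, compound 3 at 77000 nM is the higher, which makes it the weaker growth inhibitor of the pair, and compound 2 reads 9000 nM. Compound 4 `O=S(=O)(/C=C/c1ccc(O)cc1)Cc1ccc(Nc2ncnc3ccccc23)cc1` differs from compound 3 by hydroxy in place of chloro on an aromatic carbon, para to a large group.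

Going by the values given here, the only measured step, an at least 1.2-fold lower number from compound 1 to compound 3 (0.11 log units; that floor lies within the scatter), exchanges one halogen for another and says little about hydroxy. Compound 2 also carries a hydroxy, alongside other groups, and its 9000 nM hints at a lower number. The expected step is a 2.2-fold lower number from compound 3 to compound 4 (0.34 log units; beyond the scatter), a moderate move down in this assay with wide uncertainty. For compound 4 the estimate is 35000 nM, with an expected range of 10000 nM to 100000 nM.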

Compound 4, concentration for 50% growth inhibition: 100000 nM
The estimate for compound 4 lay 2.9-fold (0.46 log units) below the measured number; measured number inside the range.
By their numbers in this assay, from the lowest: compound 2; then compounds 3 and 4 (each within the scatter of the next).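

In this assay, going by these compounds alone, the first step at this position away from a halogen gives a 1.3-fold higher number from compound 3 to compound 4 (0.11 log units; within the scatter), so hydroxy and chloro, para to a large group, cannot be told apart here. The hydrogen-bond donor and acceptor that hydroxy brings make no readable difference to growth inhibition on this core. The other new step gives a number no higher from compound 1 to compound 4 (the limit leaves the size open) and its size cannot be read. Compound 1 carries a limit and not a number: the limit of > 100000 nM in this assay, at which 1 of the 4 values shown sits.

Going by these compounds, whether an amine, a methoxy or a carboxylic acid at this position would move the number beyond the scatter stays open. So does whether hydroxy would read the same with further groups on this ring.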